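This account rests on a few compounds, and the source may have more. Where it says the series, first, only, none or still open, it means among the compounds named here.

Measured so far:
compound 1, `ClCc1ccccc1Cn1cnc2c(Cl)nc(Cl)nc21`, 3270 nM
compound 2, `ClCc1ccccc1Cn1cnc2c(Cl)ncnc21`, 13800 nM
compound 3, `ClCc1ccccc1Cn1cnc2ncnc(Cl)c21`, 15800 nM

All three were tested in a functional assay on NCI-H322M cells (Homo sapiens) for cytotoxicity, read by sulforhodamine B assay, with a stated time of 48 h; on this read-out higher numbers stand for weaker inhibition of growth and lower numbers for stronger inhibition of growth. Compound 2 and compound 3 share the same atoms joined differently; how the two cores differ is not broken down here, and their values lie within the scatter of one another. Compound 1 differs from compound 2 by one change, (chloro in place of hydrogen on an aromatic carbon), and that step made a 4.2-fold lower number from compound 2 to compound 1 (0.63 log units; beyond the scatter) in this assay.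

Compound 4, `ClCc1ccccc1Cn1cnc2nc(Cl)nc(Cl)c21`, has not yet been measured. It differs from compound 3 by chloro in place of hydrogen on an aromatic carbon, the same change as from compound 2 to compound 1, made on the core of compound 3 instead. Because the earlier step gave a 4.2-fold lower number from compound 2 to compound 1 (0.63 log units; beyond the scatter), a step of similar size is expected here, so for compound 4 the estimate is a 4.0-fold lower number from compound 3 to compound 4 (0.60 log units; beyond the scatter) in this assay. Going by the values given here, since only one earlier example of this change exists, the estimate is uncertain. Compound 4 is expected to give about 4000 nM, likely between 1500 nM and 10000 nM.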

Compound 4, concentration for total growth inhibition: 14500 nM
Estimate against measurement, compound 4: 3.6-fold (0.56 log units) below; the whole stated range lies below it.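

In this assay, chloro in place of hydrogen on the core of compound 3 gave a 1.1-fold lower number from compound 3 to compound 4 (0.04 log units; within the scatter), so on this core the added chloro, sitting between two ring nitrogen atoms, makes no difference that can be told from the scatter. Set beside the earlier step, the same change did not carry over from one core to the other: the same change on two cores in this assay, a 4.2-fold lower number (0.63 log units; beyond the scatter) from compound 2 to compound 1 and a 1.1-fold lower number (0.04 log units; within the scatter) from compound 3 to compound 4, 3.9-fold (0.59 log units) apart, beyond the scatter of two such steps. Going by these compounds alone, this shows that the step seen on the core of compound 2 cannot be taken as a rule for the whole series, but with only one pair on each core it does not show why the two cores differ or how the change would behave on a further core.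

The compounds shown carry only chloro or hydrogen at this place, so it remains open whether another group, such as an amine or a methoxy group, would also give different steps on the two cores. Going by these compounds, it also remains open whether the difference between the two steps would appear in other cell lines.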